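Aryl swap on the benzyl arm: outlook for compound 4

The source may hold more compounds than are shown below. What is called first, only, known or untested is meant among the compounds shown, and "the series" means these compounds.

Compound 2 `O=c1ccoc2cc(OCc3cn(Cc4cccc(F)c4)nn3)ccc12` gives 7550 nM in a functional assay on HeLa cells (Homo sapiens) for cytotoxicity, read by MTT assay, with a stated time of 48 h (a higher number here means a weaker inhibitor, a lower number a stronger inhibitor), the lowest number among the three measured, with compound 1 `O=c1ccoc2cc(OCc3cn(Cc4ccc(Cl)cc4)nn3)ccc12` at 37600 nM. Compound 3 `N#Cc1cccc(Cn2cc(COc3ccc4c(=O)ccoc4c3)nn2)c1` reaches only the limit of > 100000 nM in this assay. Compound 4 `COc1ccc(Cn2cc(COc3ccc4c(=O)ccoc4c3)nn2)cc1` differs from compound 2 by 4-methoxyphenyl in place of 3-fluorophenyl on a saturated chain carbon bound to an aromatic nitrogen. For the measured compounds named here, two measured steps touch that same position and both leave compound 2 with the lowest number: a 5.0-fold lower number from compound 1 to compound 2 (0.70 log units; beyond the scatter) and an at least 13-fold higher number from compound 2 to compound 3 (1.12 log units; beyond the scatter), the latter bounded by the limit of > 100000 nM in this assay, at which 1 of the 3 values shown sits. Every replacement of 3-fluorophenyl seen so far gives a higher number, so a modest rise beyond the scatter is expected for compound 4, a 3.3-fold higher number from compound 2 to compound 4 (0.52 log units; beyond the scatter). Compound 4 is therefore estimated at 25000 nM in this assay, within 8000 nM to 100000 nM.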

Compound 4, half-maximal inhibitory concentration: 14400 nM
For compound 4 the middle estimate is 1.7-fold (0.24 log units) above the measured one; the measured number falls inside the stated range.
By their numbers in this assay, from the lowest: compounds 2 and 4 (each within the scatter of the next); then compound 1. At a limit, above all of these: compound 3.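

So far every replacement of 3-fluorophenyl at this place had moved the number beyond the scatter, but 4-methoxyphenyl does not in this assay: a 1.9-fold higher number from compound 2 to compound 4 (0.28 log units; within the scatter). Methoxy in place of chloro on an aromatic carbon also counts here: a 2.6-fold lower number from compound 1 to compound 4 (0.42 log units; beyond the scatter). The 3-cyanophenyl partner stays apart, an at least 6.9-fold lower number from compound 3 to compound 4 (0.84 log units; beyond the scatter), and that step is bounded by a limit: the limit of > 100000 nM in this assay, at which 1 of the 4 values shown sits.

Still open, going by these compounds, is how an amine or a carboxylic acid in place of methoxy would read in this assay. Also open, on these data alone, is whether a longer chain at this place would keep compound 4 within the scatter of compound 2.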